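Series notes: pyridin-4-yl for 4-(trifluoromethyl)phenyl

The source may hold more compounds than are shown below. What is called first, only, known or untested is meant among the compounds shown, and "the series" means these compounds.

Two members of the shared core have been run in a physicochemical assay for solubility, using the shake flask method, in simulated intestinal fluid, measured as kinetic solubility, with a stated time of 2 h, at 25 degrees C, at pH 6.5; on this read-out higher numbers stand for higher solubility and lower numbers for lower solubility. Compound 1 `Cc1nc(C(=O)N(C)C)c(N)c2c1C(=O)N(Cc1ccccc1)C2=O` gives 172000 nM. Compound 2 `Cc1noc(-c2nc(C)c3c(c2N)C(=O)N(Cc2ccc(C(F)(F)F)cc2)C3=O)n1` returns only a limit of the assay, < 5000 nM, so no number is known for it. Compound 2 therefore stands at the limit of < 5000 nM in this assay, at which 1 of the 2 values shown sits, while compound 1 is the one numbered point in the series, and the two values differ beyond the scatter.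

Compound 3 `Cc1noc(-c2nc(C)c3c(c2N)C(=O)N(Cc2ccncc2)C3=O)n1` has not yet been measured in this assay. Its difference from compound 2 is pyridin-4-yl in place of 4-(trifluoromethyl)phenyl on a saturated chain carbon bound to an amide-type nitrogen in a ring. Among the compounds with values here, no measured step between compounds that differ in one place is available, so there is nothing to size the change against directly.

The estimated step of an at least 6.0-fold higher number from compound 2 to compound 3 (0.77 log units; beyond the scatter) in this assay is expected to be upward and beyond the usual scatter. Compound 3 is estimated at 30000 nM in this assay. The expected range for compound 3 runs from 5000 nM to 150000 nM, with a fair chance that the assay again reports only a limit.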

Compound 3, solubility: 26400 nM
Compound 3: middle estimate off by 1.1-fold (0.06 log units), on the high side, and the stated range covers the measured number.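

In this assay, pyridin-4-yl in place of 4-(trifluoromethyl)phenyl on a saturated chain carbon bound to an amide-type nitrogen in a ring gives an at least 5.2-fold higher number from compound 2 to compound 3 (0.72 log units; beyond the scatter). Within the data shown here, this is the first change that can be read at one place, and it shows that this position alone can move the read-out beyond the scatter. Compound 3 gives a true number of 26400 nM. The size of the step is only a lower bound, because compound 2 has a limit of the assay and not a number: the limit of < 5000 nM in this assay, at which 1 of the 3 values shown sits.

The compounds shown do not separate what the incoming ring nitrogen of pyridin-4-yl contributes from what the departing trifluoromethyl contributes, and compound 1 differs from compound 3 in more than one place, so it cannot settle this. On these data alone, how a pyridin-2-yl group, or a phenyl ring carrying a carboxylic acid or an amine, would read at this place in this assay remains open, as does whether the step would hold on a different substituent elsewhere on the shared core.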